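The source may report more compounds than this note shows. Statements on the series, on what has been measured and on what is new or still open speak of the compounds shown alone.

Measured so far:
Compound 1, `CCCCC(CCCC)Nc1nc(C)nc2c1nnn2-c1ccc(C(C)C)cc1Br` — in an in vitro assay on 293-EBNA cells for binding affinity to corticotropin-releasing factor receptor 1 (Homo sapiens) (a lower number here means a stronger inhibitor, a higher number a weaker inhibitor), compound 1 gives 4.5 nM.
Compound 2, `CCC(COC)Nc1nc(C)nc2c1nnn2-c1ccc(C(C)C)cc1Br` — in this assay compound 2 gives 7.5 nM; 6.1 nM; 9.4 nM (3 entries).

Within the data shown here, compound 1 carries the only single number among the compounds with a long side chain attached through nitrogen to the shared core, and the repeated entries of compound 2, (the several entries of compound 2 in this assay, 7.5 nM; 6.1 nM; 9.4 nM (3 entries)), sit close to that number, so both belong to the same potent group.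

Compound 3, `CCC(COC)Oc1nc(C)nc2c1nnn2-c1ccc(C(C)C)cc1Br`, has not yet been measured. It departs from compound 1 by a group of 7 heavy atoms (5 carbon, 2 oxygen; no ring) in place of a group of 10 heavy atoms (9 carbon, 1 nitrogen; no ring), on an aromatic carbon: the nitrogen-linked chain gives way to a 1-(methoxymethyl)propoxy group attached through oxygen. From the compounds shown here alone, the same methoxymethyl-propyl chain, still attached through nitrogen, stands in compound 2 and changes little against compound 1; what remains untested is the switch of the linking atom.

A moderate step from compound 1 to compound 3 toward weaker binding is expected in this assay, with some chance of no change beyond the scatter. The value for compound 3 is estimated at 30 nM, within 8 nM to 150 nM, which corresponds to an expected step of a 6.7-fold higher number from compound 1 to compound 3 (0.82 log units; beyond the scatter).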

Compound 3, inhibition constant: 1.9 nM
Estimate against measurement, compound 3: 16-fold (1.20 log units) above; measured number outside the range, below it.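

On this aromatic carbon, next to the ring nitrogen, a linking oxygen in place of the linking nitrogen does not cost binding in this assay: the change to the 1-(methoxymethyl)propoxy group gives a 2.4-fold lower number from compound 1 to compound 3 (0.37 log units; beyond the scatter), a modest gain. The entering group has 0 hydrogen-bond donors where the leaving group has 1, so a donor at this spot is not needed for a low number in these compounds. Compound 2 shows the effect of the linking atom most directly, as it carries the same chain through nitrogen and differs from compound 3 in that one atom, and with compound 3 at 1.9 nM, every entry of compound 2 is a higher number: the several entries of compound 2 in this assay, 7.5 nM; 6.1 nM; 9.4 nM (3 entries)

From the compounds shown here alone, all of this rests on a single oxygen-linked compound, so it remains open whether the oxygen link would give a similar result with the longer chain of compound 1 or with a shorter chain such as a plain propoxy group. Also open, going by these compounds, is how other linking atoms would compare, such as sulfur in a thioether or carbon in a methylene group, and whether the methoxy end of the chain could give way to a hydroxyl group.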